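Aryl exchange from compound 3 to compound 4

The source may report more compounds than this note shows. Statements on the series, on what has been measured and on what is new or still open speak of the compounds shown alone.

In a functional assay on HCT-116 cells (Homo sapiens) for antiproliferative activity, read by MTT assay, with a stated time of 48 h (a lower number here means a stronger inhibitor, a higher number a weaker inhibitor), compound 3 `COc1ccc(-c2cc3c(cn2)[nH]c(=O)n3-c2cc(OC)c(OC)c(OC)c2)cn1` gives 830 nM. Compound 1 `COc1ccc(-c2cc3c(cn2)[nH]c(=O)n3-c2cc(OC)c(OC)c(OC)c2)cc1F` gives 910 nM, which leaves the two level, with a 1.1-fold lower number from compound 1 to compound 3 (0.04 log units; within the scatter). Compound 2 `COc1ccc(-c2cc3c(cn2)[nH]c(=O)n3-c2cc(OC)c(OC)c(OC)c2)cc1O` gives 340 nM, the lowest number of the three, and the comparison with compound 3 is a 2.4-fold higher number from compound 2 to compound 3 (0.39 log units; beyond the scatter).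

Compound 4 `CCOc1ccc(-c2cc3c(cn2)[nH]c(=O)n3-c2cc(OC)c(OC)c(OC)c2)cc1F` carries 4-ethoxy-3-fluorophenyl in place of 6-methoxypyridin-3-yl on an aromatic carbon. The closest measured exchange is a 1.1-fold lower number from compound 1 to compound 3 (0.04 log units; within the scatter), which swaps a 3-fluoro-4-methoxyphenyl group for the same 6-methoxypyridin-3-yl group and stays within the scatter. The other measured change on this aryl group, a 2.7-fold lower number from compound 1 to compound 2 (0.43 log units; beyond the scatter), is modest, but it introduces a hydroxy group that compound 4 does not carry. Among the measured compounds shown here, no measured step tests an ethoxy group, so the range is kept wide. No step beyond the scatter is expected in this assay, with a slight lean towards a higher number.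

The expected step is a 1.2-fold higher number from compound 3 to compound 4 (0.08 log units; within the scatter).

For compound 4 the estimated value is 1000 nM, within an expected range of 400 nM to 2800 nM.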

Compound 4, half-maximal inhibitory concentration: 7220 nM
Estimate against measurement, compound 4: 7.2-fold (0.86 log units) below; the measured number lies above the stated range.
By their numbers in this assay, from the lowest: compound 2; then compounds 3 and 1 (each within the scatter of the next); then compound 4.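

In this assay, the replacement of hydrogen by methyl on the saturated chain carbon, which turns the methoxy group into ethoxy, gives a 7.9-fold higher number from compound 1 to compound 4 (0.90 log units; beyond the scatter) and so exceeds every step among compounds 1, 2 and 3. Among the compounds shown here, the exchanges of 4-ethoxy-3-fluorophenyl for the other aryl groups give an 8.7-fold higher number from compound 3 to compound 4 (0.94 log units; beyond the scatter) and a 21-fold higher number from compound 2 to compound 4 (1.33 log units; beyond the scatter), and the second of these is the only step rated large, so this position responds more to the alkoxy chain than the earlier aryl changes suggested. Nothing available on these compounds accounts for this step.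

Open, on these data alone, is whether a propoxy or longer chain raises the number further, or whether an amine or a carboxylic acid at the end of that chain restores activity. Also open, as far as these compounds go, is whether ethoxy has the same effect alongside a hydroxy group in place of the fluoro, or on the 6-methoxypyridin-3-yl ring in place of its methoxy.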